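Replacing cyano with hydroxy in compound 2

The source may report more compounds than this note shows. Statements on the series, on what has been measured and on what is new or still open speak of the compounds shown alone.

In a functional assay on MCF7 cells (Homo sapiens) for antiproliferative activity, read by CellTiter-Glo, with a stated time of 5 days (on this read-out higher numbers stand for weaker inhibition and lower numbers for stronger inhibition), compound 2 (`CC1=C(c2ccc(C#N)cc2)C(c2ccc(OC[C@H](C)N3CC[C@@H](C)C3)cc2)Oc2ccc(O)cc21`) gives 10 nM, the highest of the three numbers. Compound 1 (`CC1=C(c2cccc(O)c2)[C@H](c2ccc(OC[C@H](C)N3CC[C@@H](C)C3)cc2)Oc2ccc(O)cc21`) gives 0.1 nM and compound 3 (`CC1=C(c2cccc(O)c2)C(c2ccc(OC[C@@H](C)N3CC[C@@H](C)C3)cc2)Oc2ccc(O)cc21`) gives 0.2 nM. Both carry a hydroxyphenyl group where compound 2 has its 4-cyanophenyl, and they are separated only by a 2.0-fold higher number from compound 1 to compound 3 (0.30 log units; within the scatter). Compound 4 (`CC1=C(c2ccc(O)cc2)C(c2ccc(OC[C@H](C)N3CC[C@@H](C)C3)cc2)Oc2ccc(O)cc21`) differs from compound 2 in one group: hydroxy in place of cyano on an aromatic carbon. For the measured compounds named here, no measured step covers this exact change, and the hydroxy group of compound 4 sits elsewhere on the ring than in compound 1. Compound 3 at 0.2 nM is still the closest guide, so a large drop beyond the scatter is expected in this assay. The estimated step is a 33-fold lower number from compound 2 to compound 4 (1.52 log units; beyond the scatter). Compound 4 is expected at 0.3 nM, within a range of 0.08 nM to 1.5 nM.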

Compound 4, half-maximal inhibitory concentration: 0.1 nM
The estimate for compound 4 lay 3.0-fold (0.48 log units) above the measured number, and the stated range covers the measured number.
By their numbers in this assay, from the lowest: compounds 1, 4 and 3 (each within the scatter of the next); then compound 2.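

In this assay, hydroxy in place of the nitrile on an aromatic carbon, para to a large group, gives a 100-fold lower number from compound 2 to compound 4 (2.00 log units; beyond the scatter), with the rest of the structure held. For the compounds shown here, this isolates the change for the first time, as the earlier hydroxyphenyl compounds carried the hydroxy group elsewhere on the ring. Nothing at hand explains the size of this step.

Left open is how an amine, a methoxy group or a carboxylic acid on the same carbon would compare with hydroxy and cyano. Also open, going by these compounds, is how the separate stereoisomers of compound 4 would read.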